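The source may report more compounds than this note shows. Statements on the series, on what has been measured and on what is new or still open speak of the compounds shown alone.

Three measured compounds share one core and differ only in the group on the carbonyl carbon at the end of the double-bonded chain. In an assay on a protein complex for inhibition of CDK8/Cyclin C (Homo sapiens), with a stated time of 1 h (on this read-out lower numbers stand for stronger inhibition and higher numbers for weaker inhibition), compound 1 `O=C(O)/C=C/c1ccncc1-c1ccc2ccccc2c1`, which carries a hydroxy on that carbonyl carbon, gives 5 nM. Compound 2 `COC1CN(C(=O)/C=C/c2ccncc2-c2ccc3ccccc3c2)C1`, with a 3-methoxyazetidin-1-yl in that place, gives 42.8 nM in this assay. Compound 3 `COC(=O)/C=C/c1ccncc1-c1ccc2ccccc2c1`, with a methoxy on the carbonyl carbon, gives 40.6 nM in this assay, the second highest of the three numbers: it sits close to compound 2 and well apart from compound 1. The steps recorded so far are an 8.6-fold higher number from compound 1 to compound 2 (0.93 log units; beyond the scatter) and an 8.1-fold higher number from compound 1 to compound 3 (0.91 log units; beyond the scatter), both beyond the scatter, and a 1.1-fold lower number from compound 2 to compound 3 (0.02 log units; within the scatter), which lies within it.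

Compound 4 `O=C(/C=C/c1ccncc1-c1ccc2ccccc2c1)N1CCOCC1` differs from compound 3 in one place: morpholin-4-yl in place of methoxy on a carbonyl carbon. Within the data shown here, the step that bears most directly on this change is the one between compound 2 and compound 3, since compound 2 already carries a nitrogen-linked ring on the carbonyl carbon and its number is within the scatter of compound 3. The two larger steps both start from the hydroxy compound 1 and are not retraced here. Compound 4 is therefore expected to show no step beyond the scatter, that is a 1.1-fold higher number from compound 3 to compound 4 (0.04 log units; within the scatter). Compound 4 is estimated at 45 nM in this assay, with a range from 18 nM to 120 nM.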

Compound 4, half-maximal inhibitory concentration: 60.3 nM
The estimate for compound 4 lay 1.3-fold (0.13 log units) below the measured number; the measured number falls inside the stated range.
By their numbers in this assay, from the lowest: compound 1; then compounds 3, 2 and 4 (each within the scatter of the next).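

In this assay, morpholin-4-yl on the carbonyl carbon in place of methoxy brings the group from 2 to 6 heavy atoms and adds a six-membered non-aromatic ring, yet the result is a 1.5-fold higher number from compound 3 to compound 4 (0.17 log units; within the scatter) and so no change beyond the scatter. Exchanging 3-methoxyazetidin-1-yl for morpholin-4-yl also makes no difference beyond the scatter, with a 1.4-fold higher number from compound 2 to compound 4 (0.15 log units; within the scatter) as the step, so the three groups that lack the hydroxy cannot be told apart at this position. Compound 1 remains the exception, now with a 12-fold higher number from compound 1 to compound 4 (1.08 log units; beyond the scatter) as a large step, and among these four compounds the hydroxy alone stands apart from the rest, with none going against that pattern.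

Nothing available explains why compound 1 separates from the other three. The compounds shown leave open whether an unsubstituted amino group or a piperazin-1-yl on the carbonyl carbon would stay with compounds 2, 3 and 4 or come close to compound 1, and whether a longer chain ending in a carboxylic acid would keep the number of compound 1.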